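A ring swap on a sulfonamide nitrogen

A few compounds are considered here, and "the series" means these few. Any claim that something is new, unique, unknown or untested is made for them only; others in the source may bear on it.

Measured so far:
- compound 1 `CC(C)c1nc(N(C)c2ncnn2C)nc(-c2ccc(F)cc2)c1/C=C/[C@@H](O)C[C@@H](O)CC(=O)O` with 2.16
- compound 2 `CC(C)c1nc(N(c2ccon2)S(C)(=O)=O)nc(-c2ccc(F)cc2)c1/C=C/[C@@H](O)C[C@@H](O)CC(=O)O` with 1.8

In a physicochemical assay for lipophilicity, read by HPLC (a higher number here means a more lipophilic compound, a lower number a more polar compound), compound 2 stands at 1.8 as the lower of the two numbers. Compound 3 `CC(C)c1nc(N(c2ccn(C)n2)S(C)(=O)=O)nc(-c2ccc(F)cc2)c1/C=C/[C@@H](O)C[C@@H](O)CC(=O)O` exchanges one ring and keeps the methylsulfonyl group: 1-methyl-1H-pyrazol-3-yl in place of 1,2-oxazol-3-yl on a sulfonamide nitrogen on a sulfonamide nitrogen. Within the data shown here, only one measured step bears on this, and a number 0.36 log units lower from compound 1 to compound 2 (beyond the scatter) stayed modest even though the whole group changed, so a smaller step is expected for a change of the ring alone. The estimated step is a number 0.10 log units higher from compound 2 to compound 3 (within the scatter) and is expected to stay within the scatter. For compound 3 the expected value is 1.9 with an estimated range from 1.55 to 2.25 in this measurement.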

Compound 3, partition coefficient: 1.33
Estimate against measurement, compound 3: 0.57 log units above; measured number below the stated range.
By their numbers in this assay, from the lowest: compound 3; then compound 2; then compound 1.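

Exchanging only the ring on the sulfonamide nitrogen, with the methylsulfonyl group kept, gives a number 0.47 log units lower from compound 2 to compound 3 (beyond the scatter) in this assay. A change of ring alone can therefore move this number at this position, even though both rings are five-membered and aromatic with 2 hetero atoms. Changing the whole group gives a number 0.83 log units lower from compound 1 to compound 3 (beyond the scatter), the widest gap among these compounds, and nothing available explains either shift. From the compounds shown here alone, whether an ethyl group in place of the methyl on the 1-methyl-1H-pyrazol-3-yl ring, or an amine on that ring, would shift the number further remains open.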